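The compounds below may be only part of what the source reports. "The series", "measured", "known", "first", "only" and "open" are said of these compounds alone.

Of the compounds shown here, three have been measured in a functional assay on Jurkat cells (Homo sapiens) for activation, with a stated time of 24 h; on this read-out higher numbers stand for an effect only at larger amounts of compound and lower numbers for an effect already at smaller amounts. Compound 1 `COc1ccc(-c2ccc(NCc3ccccc3O)cc2)cc1` gives 580 nM, and compound 2 `CCOc1ccc(-c2ccc(NCc3ccccc3O)cc2)cc1` gives 520 nM. The two differ by methyl in place of hydrogen on a saturated chain carbon bound to an oxygen on an aromatic ring, and the step of a 1.1-fold lower number from compound 1 to compound 2 (0.05 log units; within the scatter) is a small one. Compound 3 `Oc1ccccc1CNc1ccc(C2CCCCC2)cc1` gives 8800 nM in this assay, the highest number of the three and well apart from both compound 1 and compound 2; its core differs from that of compound 1, but the difference between the two cores is not broken down here.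

Compound 4 `CC(Nc1ccc(C2CCCCC2)cc1)c1ccccc1O` has not yet been measured. It differs from compound 3 by methyl in place of hydrogen on a saturated chain carbon bound to an aromatic carbon and a nitrogen on an aromatic ring. For the measured compounds named here, this is the same kind of change as the one from compound 1 to compound 2, but not the same: there the entering methyl sits on a saturated chain carbon bound to an oxygen on an aromatic ring, whereas here it sits on a saturated chain carbon bound to an aromatic carbon and a nitrogen on an aromatic ring.

Going by the values given here, the only precedent is the step from compound 1 to compound 2, which stayed within the scatter, and on that basis the expected step from compound 3 to compound 4 is likewise small, a 1.1-fold higher number from compound 3 to compound 4 (0.03 log units; within the scatter). Compound 4 is therefore estimated at 9500 nM in this assay, with a likely range from 3500 nM to 25000 nM, the width reflecting that the surroundings of the change differ from the measured precedent.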

Compound 4, half-maximal effective concentration: "not active" (no number reported)
For compound 4 the study gives words and no number; there is nothing to compare the estimate with.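

In this assay, for the compounds shown here, compound 4 is reported only in words, as not active, so no step from compound 3 to compound 4 can be read. Nothing measured here accounts for this result. The compounds shown leave open how far methyl in place of hydrogen on this saturated chain carbon shifts the read-out, if compound 4 has any number at all.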